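A few compounds are considered here, and "the series" means these few. Any claim that something is new, unique, unknown or untested is made for them only; others in the source may bear on it.

Measured compounds:
compound 1, `O=S(=O)(Nc1ccc2oc(-c3ccccc3)nc2c1)c1cccc(C(F)(F)F)c1`, > 63000 nM
compound 2, `O=S(=O)(Nc1ccc(-c2nc3ccccc3o2)cc1)c1cccc(Cl)c1`, > 63000 nM
compound 3, `O=S(=O)(Nc1ccc2oc(-c3ccccc3)nc2c1)c1ccccc1O`, > 63000 nM

In an assay on isolated protein for inhibition of malate dehydrogenase, mitochondrial (Sus scrofa), with stated times of 45 min and 30 min (on this read-out higher numbers stand for weaker inhibition and lower numbers for stronger inhibition), compound 1 gives > 63000 nM, which is a limit of the assay rather than a number. Compound 2 gives > 63000 nM in this assay, again a limit. Compound 3 likewise gives > 63000 nM, also a limit. Compound 2 therefore stands where every value shown stands, at the limit of > 63000 nM in this assay, at which 3 of the 3 values shown sit, and nothing in these numbers sets it apart from compound 1 or compound 3.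

Compound 4, `O=S(=O)(Nc1ccc(-c2nc3ccccc3o2)cc1)c1ccc(Cl)cc1`, has not yet been measured in this assay. It differs from compound 2 in a single place: 4-chlorophenyl in place of 3-chlorophenyl on a sulfonyl sulfur. No step between measured compounds is shown, so the expectation rests on the shared limit alone. The step expected is a step that the limit leaves unreadable from compound 2 to compound 4, that is, none beyond the scatter. The value estimated for compound 4 is 80000 nM, within a range from 30000 nM to 200000 nM, and it is expected most likely to be reported again as a limit.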

Compound 4, half-maximal inhibitory concentration: > 63000 nM
Compound 4 was reported as a limit; the forecaster's own chance of this, stated with the estimate: 85%; the middle value is on the limit's open side.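

Compound 2 and compound 4 both stand as limits in this assay, so no step can be read between them: the limit of > 63000 nM in this assay, at which 4 of the 4 values shown sit. The compounds shown leave open whether 4-chlorophenyl and 3-chlorophenyl on a sulfonyl sulfur differ at all, and what a measurable value in this assay would look like.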